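The source may hold more compounds than are shown below. What is called first, only, known or untested is meant among the compounds shown, and "the series" means these compounds.

Of the compounds shown here, three sharing one core have been tested in a toxicity assay on HUVEC cells (Homo sapiens) for inhibition; a lower number here means a stronger inhibitor of growth, a higher number a weaker inhibitor of growth. Among the measured compounds shown here, compound 1 `O=C(OCC(F)(F)F)c1ccsc1NC(=O)[C@@H]1CCCN1` reaches only a limit of the assay, reported as > 250 ug/mL, so no number is known for it; the limit of > 250 ug/mL in this assay, at which 1 of the 3 values shown sits, records it as the one value sitting there. Compound 2 `COC(=O)c1sccc1NC(=O)[C@@H]1CCCN1` gives 91.4 ug/mL in this assay, and compound 3 `COC(=O)c1ccsc1NC(=O)[C@H]1CCCN1` gives 95.8 ug/mL, the two lying within the usual scatter of each other. Compound 4 `O=C(OCC(Cl)(Cl)Cl)c1ccsc1NC(=O)[C@@H]1CCCN1` differs from compound 1 in one place: trichloromethyl in place of trifluoromethyl on a saturated chain carbon bound to an oxygen next to a carbonyl group. For the measured compounds named here, no measured pair shows this change, so the expectation rests on compound 1 alone. Compound 4 is expected to stay close to that limit, the expected step of an at least 1.2-fold lower number from compound 1 to compound 4 (0.09 log units; that floor lies within the scatter) amounting to little beyond the scatter. Compound 4 is therefore estimated at 200 ug/mL, with a range from 70 ug/mL to 500 ug/mL.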

Compound 4, concentration for 50% growth inhibition: > 250 ug/mL
Compound 4: a limit, no number; the forecaster's own chance of this, stated with the estimate: 50%; middle value at least 1.2-fold (0.09 log units) from the limit.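

In this assay, among the compounds shown here, compound 1 and compound 4 each reach only a limit, so no step between them can be read. On these data alone, whether trichloromethyl in place of trifluoromethyl changes growth inhibition at all, and by how much, stays open.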